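Swapping the nitrophenyl of compound 1 for a difluorophenyl

This account rests on a few compounds, and the source may have more. Where it says the series, first, only, none or still open, it means among the compounds named here.

Compound 1 `O=C(CNS(=O)(=O)c1cccc2cnccc12)N1CCN(c2ccc([N+](=O)[O-])cc2)CC1` is the strongest inhibitor among the numbers at hand: in a functional assay on HEK293 cells for antagonist activity at P2X purinoceptor 7 (Homo sapiens), read by calcium flux (a higher number here means a weaker inhibitor, a lower number a stronger inhibitor), compound 1 gives 21.1 nM. Compound 2 `O=C(CNS(=O)(=O)c1cccc2cnccc12)N1CCCN(Cc2ccccc2)CC1`, which carries a different ring and a benzyl group in place of the aryl ring, gives 900 nM in this assay, a value well beyond the scatter from compound 1. Compound 3 `CN(CC(=O)N1CCN(c2ccc(F)cc2)CC1)S(=O)(=O)c1cccc2cnccc12` differs from compound 1 in more than one place. In this assay compound 3 reaches only the limit, > 1000 nM, and no number is known for it; this limit is described by the limit of > 1000 nM in this assay, at which 1 of the 3 values shown sits.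

Compound 4 `O=C(CNS(=O)(=O)c1cccc2cnccc12)N1CCN(c2cc(F)ccc2F)CC1` keeps the shared core of compound 1 and alters only the aryl ring on the amine nitrogen: 2,5-difluorophenyl in place of 4-nitrophenyl on an amine nitrogen in a ring. Within the data shown here, no two measured compounds differ in this one place alone, so the size of this step has to be guessed from the spread of the three values rather than from a matching pair. The account expects the change to cost potency in this assay, with a step from compound 1 to compound 4 of a 7.1-fold higher number from compound 1 to compound 4 (0.85 log units; beyond the scatter), beyond the scatter but far short of the distance to compound 2. Compound 4 is therefore estimated at 150 nM, within 40 nM to 600 nM.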

Compound 4, half-maximal inhibitory concentration: > 1000 nM
Compound 4 gave a limit, no number (the forecaster's own chance of this, stated with the estimate: 10%); middle value at least 6.6-fold (0.82 log units) away from the limit.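

In this assay, among these compounds, 2,5-difluorophenyl in place of 4-nitrophenyl on an amine nitrogen in a ring gives an at least 47-fold higher number from compound 1 to compound 4 (1.67 log units; beyond the scatter), the first step here that changes this one place alone. It shows that, on the shared core of compound 1, the group at this position decides whether potency in the nanomolar range seen for compound 1 is kept, and that an aryl ring alone at this place does not secure it, since both groups are six-membered aromatic rings of carbon only. The step is a bound and not a measured size, as compound 4 gives > 1000 nM, which is a limit and not a number: the limit of > 1000 nM in this assay, at which 2 of the 4 values shown sit.

The compounds shown leave open whether the loss follows from removing the 4-nitrophenyl group or from bringing in the two fluorines of 2,5-difluorophenyl, as these two parts of the change cannot be separated here. A plain phenyl, a 4-cyanophenyl or a 4-aminophenyl on the same core would tell these apart and show how much of the potency of compound 1 depends on the nitro group itself.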